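Methoxy in place of hydrogen on the anilino ring

The compounds below may be only part of what the source reports. "The series", "measured", "known", "first", "only" and "open" are said of these compounds alone.

Compound 1 `Cc1nc(SCC(=O)Nc2nc(-c3ccc(Cl)cc3)cs2)n(Nc2ccccc2)c1C` carries the highest number seen so far: in a functional assay on MDA-MB-435 cells (Homo sapiens) for antiproliferative activity, read by sulforhodamine B assay, with a stated time of 48 h (a higher number here means a weaker inhibitor of growth, a lower number a stronger inhibitor of growth), compound 1 gives 21800 nM. Compound 2 `Cc1ccc(Nn2c(SCC(=O)Nc3nc(-c4ccccc4)cs3)nc(C)c2C)cc1`, which differs from it at two places, gives 9540 nM in this assay, a gap beyond the scatter. Compound 3 `COc1ccc(Nn2c(SCC(=O)Nc3nc(-c4ccc(Cl)cc4)cs3)nc(C)c2C)cc1` carries the change (methoxy in place of hydrogen on an aromatic carbon), sitting para to a large group, where compound 1 has hydrogen. Going by the values given here, no single-site step is available to size this change. A modest fall in the number is expected, a 1.7-fold lower number from compound 1 to compound 3 (0.22 log units; within the scatter). For compound 3 the estimate in this assay is 13000 nM, within 5000 nM to 32000 nM.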

Compound 3, concentration for total growth inhibition: > 100000 nM
Compound 3 gave a limit, no number; the forecaster's own chance of this, stated with the estimate: 5%; at least 7.6-fold (0.88 log units) between middle value and limit.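

On the anilino ring, at the carbon para to a large group, methoxy in place of hydrogen gives the only single-site step shown, and growth inhibition in this assay weakens, with an at least 4.5-fold higher number from compound 1 to compound 3 (0.66 log units; beyond the scatter) on this change. So this position does not tolerate every added group, and a small methoxy is enough to produce a step beyond the scatter. For compound 3 the reading is a limit and not a number: the limit of > 100000 nM in this assay, at which 1 of the 3 values shown sits.

The compounds shown leave open whether a hydroxyl, a fluorine or an amine at this carbon behaves like methoxy or like hydrogen.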